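A few compounds are considered here, and "the series" means these few. Any claim that something is new, unique, unknown or untested is made for them only; others in the source may bear on it.

Working notes on the series. Compound 3 `Oc1cc(C(F)(F)F)ccc1-c1nc(-c2ccccc2O)n(-c2ccc(C(F)(F)F)cc2)n1` gives, in a functional assay on PC-12 cells (Rattus norvegicus) for cytotoxicity, read by MTT assay, with stated times of 2 h and 24 h, tested at 10 uM (on this read-out higher numbers stand for a stronger effect at the one concentration tested and lower numbers for a weaker effect), a reading of 102%. On that number it stands level with compound 1 `Cc1ccc(-n2nc(-c3ccc(C(F)(F)F)cc3O)nc2-c2ccccc2O)cc1`, which gives 102%, the two together at the top of the three values; compound 2 `CC(C)(C)c1ccc(-n2nc(-c3ccc(C(F)(F)F)cc3O)nc2-c2ccccc2O)cc1` gives 81.1% and lies furthest from compound 3. The steps among the measured compounds, all at the same aromatic carbon of the pendant phenyl ring, read no change at the digits printed from compound 1 to compound 3 (within the scatter), a number 20.9 percentage points lower from compound 1 to compound 2 (beyond the scatter) and a number 20.9 percentage points higher from compound 2 to compound 3 (beyond the scatter).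

Compound 4 `COc1ccc(-n2nc(-c3ccc(C(F)(F)F)cc3O)nc2-c2ccccc2O)cc1` is the next member. It differs from compound 3 as follows: methoxy in place of trifluoromethyl on an aromatic carbon.

Bearing on this step are the three measured steps at that carbon. Methyl and trifluoromethyl give the same reading within the scatter; only tert-butyl moves the number, and modestly. Methoxy has not been measured anywhere in the set, so there is no direct precedent for it. With two of three groups at that site leaving the reading unchanged, the expected step from compound 3 to compound 4 is a number 7 percentage points lower from compound 3 to compound 4 (within the scatter), that is, none beyond the scatter, with the lower end of the range allowing for a modest fall of the kind seen with compound 2 at 81.1%. For compound 4 the estimate in this assay is 95%, within 75% to 110%.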

Compound 4, a percentage reported as activity, at one concentration (the size of the read-out at that concentration, not a potency): 98.9%
For compound 4 the middle estimate is 3.9 percentage points below the measured one, within the range that was stated.
By their numbers in this assay, from the lowest: compound 2; then compounds 4, 1 and 3 (each within the scatter of the next).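

In this assay, methoxy at this aromatic carbon joins methyl and trifluoromethyl as a group that leaves the reading in place, with a number 3.1 percentage points lower from compound 3 to compound 4 (within the scatter) and with a number 3.1 percentage points lower from compound 1 to compound 4 (within the scatter) for the change from methyl to methoxy. Among these compounds, compound 2 is the one compound that goes against this pattern, with a number 17.8 percentage points higher from compound 2 to compound 4 (beyond the scatter) setting tert-butyl apart from methoxy just as it stood apart from methyl and trifluoromethyl, so among the four groups at this carbon only tert-butyl moves the number beyond the scatter. Nothing on hand accounts for this grouping of the four compounds.

From the compounds shown here alone, whether an amine, a carboxylic acid or a longer chain at this same carbon would read with compound 1, compound 3 and compound 4 or would shift the number as the tert-butyl group of compound 2 does remains open. Also open, going by these compounds, is whether replacing the trifluoromethyl on the hydroxyphenyl ring of the shared core with a chlorine or a nitrile would leave the reading in place as the changes on the other aromatic ring mostly do.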